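A Halogen Swap on the Shared Core

This account rests on a few compounds, and the source may have more. Where it says the series, first, only, none or still open, it means among the compounds named here.

Compound 1, `COc1cc(/C(C)=N/Nc2nc3ccccc3nc2Cc2ccccc2)cc(OC)c1OC`: 260000 nM
Compound 2, `Clc1ccc(/C=N/Nc2nc3ccccc3nc2Cc2ccccc2)cc1`: 84000 nM
Compound 3, `C/C(=N\Nc1nc2ccccc2nc1Cc1ccccc1)c1ccc(C)cc1`: 740000 nM

Of the compounds shown here, three on the shared core have been measured in an assay on isolated protein for inhibition of Amine oxidase [flavin-containing] B (Homo sapiens), read by spectrophotometry; on this read-out higher numbers stand for weaker inhibition and lower numbers for stronger inhibition. Compound 2 holds the lowest number of the three; compound 1 sits next with a higher number, beyond the scatter, and compound 3 lies furthest, also beyond the scatter. Among the measured compounds shown here, no pair among them differs in a single place, so no measured step is available to guide what follows.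

Compound 4, `Brc1cccc(/C=N/Nc2nc3ccccc3nc2Cc2ccccc2)c1`, has not yet been measured in this assay. It departs from compound 2 in one place: 3-bromophenyl in place of 4-chlorophenyl on a carbon with a double bond to nitrogen. One halogen-bearing phenyl group is exchanged for another, and nothing in the measured set shows what such an exchange does on this core.

Without a measured step to lean on, compound 4 is expected to sit close to compound 2, with a step of a 1.2-fold higher number from compound 2 to compound 4 (0.08 log units; within the scatter) in this assay that is not expected to reach beyond the scatter. Compound 4 is therefore estimated at 100000 nM, within a range from 30000 nM to 350000 nM.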

Compound 4, half-maximal inhibitory concentration: 48000 nM
Beside the measured number, compound 4's estimate is 2.1-fold (0.32 log units) above it, within the range that was stated.
By their numbers in this assay, from the lowest: compounds 4 and 2 (each within the scatter of the next); then compound 1; then compound 3.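

In this assay, among the compounds shown here, the exchange of 4-chlorophenyl for 3-bromophenyl on a carbon with a double bond to nitrogen gives the first measured step on the shared core, with a 1.8-fold lower number from compound 2 to compound 4 (0.24 log units; within the scatter) for this change. Compound 2 and compound 4 cannot be told apart on this read-out, so this position takes this swap of one halogen-bearing phenyl group for another without a step beyond the scatter. Nothing measured here explains this result.

The step exchanges the halogen and its ring position together, so 3-bromophenyl and 4-chlorophenyl alone cannot show what either change does separately, which 3-chlorophenyl could help to settle. From the compounds shown here alone, whether this position would also take a phenyl group bearing an amine or a carboxylic acid remains open.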